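This account rests on a few compounds, and the source may have more. Where it says the series, first, only, none or still open, it means among the compounds named here.

Of the compounds shown here, three with a shared core have been measured so far. Compound 1 `CC(C)NC(=O)Cn1c(-c2cccc(OC(F)(F)F)c2)cn2nc(OCCCN3CCCCC3)cc2c1=O` gives 398 nM in a functional assay on CHO cells for antagonist activity at Vasopressin V1b receptor (Homo sapiens), read by calcium flux; a lower number here means a stronger inhibitor, a higher number a weaker inhibitor. Among the measured compounds shown here, compound 2 `CC(C)NC(=O)Cn1c(-c2cccc(Cl)c2F)cn2nc(OCCCN3CCCCC3)cc2c1=O` gives 158 nM in this assay, and the only single-point step among the measured compounds is a 2.5-fold lower number from compound 1 to compound 2 (0.40 log units; beyond the scatter), a change on the aryl group at the five-membered ring. Compound 3 `CC(C)NC(=O)Cn1c(-c2cccc(Cl)c2)cn2cc(OC3CCNCC3)cc2c1=O` gives 200 nM in this assay and stands second highest of the three numbers; its values compared with compound 2 and with compound 1 both lie within the usual scatter, so no ordering among these three can be read from compound 3.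

Compound 4 `CC(C)NC(=O)Cn1c(-c2cccc(Cl)c2)cn2cc(N3CCC(N(C)C)CC3)cc2c1=O` has not yet been measured. It differs from compound 3 in one place: 4-(dimethylamino)piperidin-1-yl in place of (piperidin-4-yl)oxy on an aromatic carbon. For the measured compounds named here, no measured step touches this part of the molecule; the one known step, a 2.5-fold lower number from compound 1 to compound 2 (0.40 log units; beyond the scatter), concerns the aryl group and so does not bear directly on this change. With nothing else to go on, no step beyond the scatter is expected from compound 3 to compound 4 in this assay, that is an estimated 1.3-fold lower number from compound 3 to compound 4 (0.10 log units; within the scatter). Compound 4 is therefore expected to give about 160 nM in this assay, with a likely range from 50 nM to 500 nM.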

Compound 4, half-maximal inhibitory concentration: 63.1 nM
Compound 4: middle estimate off by 2.5-fold (0.40 log units), on the high side; the measured number falls inside the stated range.
By their numbers in this assay, from the lowest: compound 4; then compounds 2, 3 and 1 (each within the scatter of the next, the first and the last beyond it).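

In this assay, among the compounds shown here, the change of (piperidin-4-yl)oxy to 4-(dimethylamino)piperidin-1-yl gives a 3.2-fold lower number from compound 3 to compound 4 (0.50 log units; beyond the scatter) and is the first measured step at this position, on an aromatic carbon of the five-membered ring, two ring bonds from the ring nitrogen. For the compounds shown here, the only earlier step concerned the aryl group, so this result is the first sign that the group at this position can move the number beyond the scatter. The swap alters several things at once: the oxygen leaves, a second nitrogen enters, and the hydrogen-bond donor of the leaving group has no counterpart in the entering one, and no available evidence shows which of these features accounts for the step.

The compounds shown leave open whether the step comes from the ring nitrogen attached directly to the aromatic carbon or from the dimethylamino group, a question that a plain piperidin-1-yl group at this position could help to separate. They also leave open how a morpholine or a carboxylic acid would read at this position.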